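Swapping a Saturated Ring for a Pyridine on the Chain

The source may hold more compounds than are shown below. What is called first, only, known or untested is meant among the compounds shown, and "the series" means these compounds.

Measured so far:
- compound 1 `Cn1c(CCc2ccccc2)nc2cc(Cl)c(Cl)cc21`: 15300 nM in a functional assay on HepG2 cells (Homo sapiens) for cytotoxicity; on this read-out lower numbers stand for higher toxicity in this test and higher numbers for lower toxicity in this test
- compound 2 `Cn1c(CCC2CCCO2)nc2cc(Cl)c(Cl)cc21`: 56000 nM in this assay

Compound 2 carries the highest number of the two, sitting above compound 1 by the step of a 3.7-fold higher number from compound 1 to compound 2 (0.56 log units; beyond the scatter). That single step is the only one measured, and it shows what happens when the phenyl ring on the chain is replaced by an oxolan-2-yl ring.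

Compound 3 `Cn1c(CCc2ccncc2)nc2cc(Cl)c(Cl)cc21` has not yet been measured. It differs from compound 2 by pyridin-4-yl in place of oxolan-2-yl on a saturated chain carbon, two bonds along the chain from an aromatic carbon. The pyridin-4-yl ring of compound 3 is, like the phenyl of compound 1, a six-membered aromatic ring, so the step from compound 1 to compound 2 bears on it in reverse: going from a saturated oxolane back to an aromatic ring is expected to pull the number down again in this assay.

Compound 3 is therefore estimated to give 25000 nM in this assay, within a range of 10000 nM to 70000 nM, which would be an expected step of a 2.2-fold lower number from compound 2 to compound 3 (0.35 log units; beyond the scatter).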

Compound 3, half-maximal cytotoxic concentration: 35800 nM
Beside the measured number, compound 3's estimate is 1.4-fold (0.16 log units) below it, and the stated range covers the measured number.
By their numbers in this assay, from the lowest: compound 1; then compounds 3 and 2 (each within the scatter of the next).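

In this assay, putting pyridin-4-yl in place of oxolan-2-yl on this saturated chain carbon gives a 1.6-fold lower number from compound 2 to compound 3 (0.19 log units; within the scatter), so the two groups cannot be told apart here, although one is a five-membered non-aromatic ring and the other a six-membered aromatic ring. The comparison with the phenyl compound is new: pyridin-4-yl in place of phenyl gives a 2.3-fold higher number from compound 1 to compound 3 (0.37 log units; beyond the scatter), so among these three compounds an aromatic ring at this place does not by itself go with the lowest number, and compound 1 stands apart from both others. No measurement shown gives a reason for this difference between the phenyl and pyridin-4-yl compounds.

The compounds shown leave open whether the place of the nitrogen within the aromatic ring matters, which pyridin-3-yl or pyridin-2-yl on the same chain could test. They also leave open how a saturated ring holding an amine, such as piperidin-4-yl, or a longer chain carrying the same pyridin-4-yl ring would read in this assay and compare with these three compounds.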